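Aryl amide in place of methoxyacetamide on a shared core

This account rests on a few compounds, and the source may have more. Where it says the series, first, only, none or still open, it means among the compounds named here.

Compound 3 `COCC(=O)Nc1c(C(O)(C(F)(F)F)C(F)(F)F)ccc2ccccc12` gives 204 nM in a functional assay (Sus scrofa) with sulfonylurea receptors; K-ATP channels (Homo sapiens) as the target (a higher number here means that more compound is needed for the effect, a lower number that less compound is needed), the highest of the three measured numbers; compound 1 `CC(=O)Nc1c(C(O)(C(F)(F)F)C(F)(F)F)ccc2ccccc12` gives 95.5 nM and compound 2 `CCC(=O)Nc1c(C(O)(C(F)(F)F)C(F)(F)F)ccc2ccccc12` gives 8.91 nM. Compound 4 `O=C(Nc1c(C(O)(C(F)(F)F)C(F)(F)F)ccc2ccccc12)c1ccc(Cl)cc1` differs from compound 3 by 4-chlorophenyl in place of methoxymethyl on a carbonyl carbon. Within the data shown here, no measured step exchanges a chain for an aromatic ring, but the amide substituent has moved this assay strongly: an 11-fold lower number from compound 1 to compound 2 (1.03 log units; beyond the scatter), a 2.1-fold higher number from compound 1 to compound 3 (0.33 log units; beyond the scatter), and a 23-fold higher number from compound 2 to compound 3 (1.36 log units; beyond the scatter). The entering group counts no hydrogen-bond acceptor, matching the methyl of compound 2 rather than the methoxy of compound 3, so a lower number is expected for compound 4, though the aryl group has no precedent among these compounds. Compound 4 is therefore estimated at 30 nM with a range of 5 nM to 200 nM, meaning a 6.8-fold lower number from compound 3 to compound 4 (0.83 log units; beyond the scatter).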

Compound 4, half-maximal effective concentration: 389 nM
For compound 4 the middle estimate is 13-fold (1.11 log units) below the measured one; measured number above the stated range.
By their numbers in this assay, from the lowest: compound 2; then compound 1; then compounds 3 and 4 (each within the scatter of the next).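

In this assay, the 4-chlorophenyl group counts no hydrogen-bond acceptor, like the ethyl of compound 2, yet the change to it is large (a 44-fold higher number from compound 2 to compound 4 (1.64 log units; beyond the scatter)), while the methoxymethyl of compound 3, which counts one, stays within the scatter of it (a 1.9-fold higher number from compound 3 to compound 4 (0.28 log units; within the scatter)). Acceptor count alone therefore does not order these amides at this carbonyl carbon, and the aryl amide also gives a higher number than the methyl of compound 1 (a 4.1-fold higher number from compound 1 to compound 4 (0.61 log units; beyond the scatter)). Nothing given here explains these differences.

The compounds shown leave open whether the 4-chlorophenyl result belongs to the ring or to its chlorine, which a plain phenyl would separate. They also leave open whether a propyl chain would extend the gain seen with the ethyl of compound 2.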